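From 4-methylphenyl to 4-ethylphenyl

The compounds below may be only part of what the source reports. "The series", "measured", "known", "first", "only" and "open" are said of these compounds alone.

Values measured in a functional assay on PC-3 cells (Homo sapiens) for cytotoxicity (a lower number here means that less compound is needed, a higher number that more compound is needed for the effect), are:
- compound 1 `CCC1=C(OC)C(CC)(CC)C(=O)C(C(=O)/C=C/c2ccccc2)=C1O` gives 7.7 ug/mL
- compound 2 `CCC1=C(OC)C(CC)(CC)C(=O)C(C(=O)/C=C/c2ccc(C)cc2)=C1O` gives 15 ug/mL

Compound 2 stands within the scatter of compound 1. Compound 3 `CCC1=C(OC)C(CC)(CC)C(=O)C(C(=O)/C=C/c2ccc(CC)cc2)=C1O` turns 4-methylphenyl into 4-ethylphenyl with methyl in place of hydrogen on a saturated chain carbon bound to an aromatic carbon as the difference, which is methyl in place of hydrogen on a saturated chain carbon bound to an aromatic carbon. Among the measured compounds shown here, the one measured step that bears on this is a 1.9-fold higher number from compound 1 to compound 2 (0.29 log units; within the scatter) for methyl in place of hydrogen on an aromatic carbon, so no step beyond the scatter is expected in this assay for compound 3. The expected step is no change at the digits printed from compound 2 to compound 3 (within the scatter) and so stays within the scatter. The estimate for compound 3 is 15 ug/mL with 7 ug/mL to 30 ug/mL as its expected range.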

Compound 3, concentration for half-maximal effect: 15 ug/mL
Compound 3: middle estimate and measured number agree at the digits printed; the measured number falls inside the stated range.
By their numbers in this assay, from the lowest: compounds 1, 2 and 3 (each within the scatter of the next).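

In this assay, methyl in place of hydrogen on a saturated chain carbon bound to an aromatic carbon gives no change at the digits printed from compound 2 to compound 3 (within the scatter), so extending 4-methylphenyl to 4-ethylphenyl leaves the number within the scatter. The wider comparison gives a 1.9-fold higher number from compound 1 to compound 3 (0.29 log units; within the scatter), so this larger replacement also stays within the scatter. Nothing available explains why these numbers lie so close. Still open, on these data alone, is whether a longer chain, such as butyl, would stay within the scatter at this place. An amine or a carboxylic acid there might also behave differently.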